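This account rests on a few compounds, and the source may have more. Where it says the series, first, only, none or still open, it means among the compounds named here.

Compound 2, with the structure `CC(C)(O)c1nc(-c2cccc(CNC(=O)c3ccc(-c4ccccc4)nc3)c2)no1`, was tested in an assay on isolated protein for inhibition of Hematopoietic prostaglandin D synthase (Homo sapiens), read by ELISA (a higher number here means a weaker inhibitor, a lower number a stronger inhibitor), and gave 808 nM. Within the data shown here, only one other compound has a number in this assay: compound 1, of structure `O=C(NCc1ccccc1)c1ccc(-c2ccccn2)nc1`, which in this assay gives 453 nM. The two numbers lie within the usual scatter of each other, so nothing separates compound 2 from compound 1 on this evidence, and the two compounds differ in more than one place, so no single change can be read from that pair.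

Compound 3, with the structure `CC(C)(O)c1nc(-c2cccc(CNC(=O)c3ccc(-c4ccccn4)nc3)c2)no1`, has not yet been measured in this assay. It differs from compound 2 in one place: pyridin-2-yl in place of phenyl on an aromatic carbon. Among the measured compounds shown here, no measured pair shows this exact change. Compound 1 carries the same pyridin-2-yl group, but on a different benzylic side, so its number is only a loose guide. On that basis the step is expected to be small, with no direction that can be asserted beyond the scatter, though a modest move toward a lower number is considered somewhat more likely. Compound 3 is therefore expected to fall near 450 nM, within a range from 150 nM to 1300 nM, which corresponds to an expected step of a 1.8-fold lower number from compound 2 to compound 3 (0.25 log units; within the scatter).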

Compound 3, half-maximal inhibitory concentration: 328 nM
The estimate for compound 3 lay 1.4-fold (0.14 log units) above the measured number; measured number inside the range.
By their numbers in this assay, from the lowest: compounds 3, 1 and 2 (each within the scatter of the next, the first and the last beyond it).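

In this assay, among these compounds, pyridin-2-yl in place of phenyl on the carbon next to the ring nitrogen and para to a large group gives a 2.5-fold lower number from compound 2 to compound 3 (0.39 log units; beyond the scatter) and lies beyond the scatter, though the step is modest; it is the first single change at this position that can be read, and it rests on this one pair. The second step, 5-(1-hydroxy-1-methylethyl)-1,2,4-oxadiazol-3-yl in place of hydrogen on an aromatic carbon, gives a 1.4-fold lower number from compound 1 to compound 3 (0.14 log units; within the scatter) and stays within the scatter, so with pyridin-2-yl in place, compound 3 and compound 1 cannot be told apart, and this large group can be neither credited nor blamed on this evidence. No measurement here bears on why the ring nitrogen goes with the lower number.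

From the compounds shown here alone, whether the step from phenyl holds for pyridin-3-yl, pyridin-4-yl or pyrimidin-2-yl at this position remains open. So does the effect of a methoxy group or an amine on that ring, or of an amine in place of the hydroxy group on the oxadiazole side chain.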